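A few compounds are considered here, and "the series" means these few. Any claim that something is new, unique, unknown or untested is made for them only; others in the source may bear on it.

Measured so far in a functional assay on SW 1116 cells (Homo sapiens) for cytotoxicity, read by MTT assay, with a stated time of 48 h; on this read-out lower numbers stand for stronger inhibition and higher numbers for weaker inhibition:
Compound 1 `COc1ccc(/C=N/NC(=O)CSc2nnc(-c3ccncc3)o2)cc1` gives 20300 nM.
Compound 2 `O=C(CSc1nnc(-c2ccncc2)o1)N/N=C/c1ccccc1[N+](=O)[O-]` gives 30700 nM.

Of these two numbers, compound 2 carries the larger one, yet the step from the first to the second is small: a 1.5-fold higher number from compound 1 to compound 2 (0.18 log units; within the scatter). Among the measured compounds shown here, that step swapped one substituted phenyl for another on the carbon with a double bond to nitrogen, and it is the only measured step in this set.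

Compound 3 `O=C(CSc1nnc(-c2ccncc2)o1)N/N=C/c1ccccc1O` differs from compound 2 in one place: hydroxy in place of nitro on an aromatic carbon. For the measured compounds named here, no measured pair shows a hydroxy in place of a nitro, so the only guide is the one step in this assay, which bears on the same aryl position and stayed within the scatter. On that basis no movement beyond the scatter is expected from compound 2 to compound 3, in either direction, and the expected step is a 1.2-fold lower number from compound 2 to compound 3 (0.09 log units; within the scatter). Compound 3 is therefore estimated at 25000 nM in this assay, with a plausible range from 10000 nM to 60000 nM.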

Compound 3, half-maximal inhibitory concentration: 7380 nM
Compound 3: the middle estimate sits 3.4-fold (0.53 log units) above what was measured; measured number outside the range, below it.
By their numbers in this assay, from the lowest: compound 3; then compounds 1 and 2 (each within the scatter of the next).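

In this assay the aryl group on the carbon with a double bond to nitrogen proved able to move the number beyond the scatter, which the earlier swap of one substituted phenyl for another had not shown. Hydroxy in place of nitro on an aromatic carbon gives a 4.2-fold lower number from compound 2 to compound 3 (0.62 log units; beyond the scatter) and 2-hydroxyphenyl in place of 4-methoxyphenyl gives a 2.8-fold lower number from compound 1 to compound 3 (0.44 log units; beyond the scatter) and so both modest steps point the same way, leaving compound 3 with the lowest number of the three, beyond the scatter of each of the others. No measurement at hand bears on why this change lowers the number.

The compounds shown leave open whether another group in the same place, such as an amine or a carboxylic acid, would lower the number as hydroxy does. Among the compounds shown here, they also leave open whether hydroxy would give a similar result elsewhere on the ring, since compound 3 is the only compound here that carries it, ortho to a large group.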